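Swapping a sulfonyl cap for a pyridine amide

The source may hold more compounds than are shown below. What is called first, only, known or untested is meant among the compounds shown, and "the series" means these compounds.

Of the compounds shown here, three sharing one core have been tested in a functional assay on HCT-116 cells (Homo sapiens) for inhibition, read by luminescence and resazurin assay, with a stated time of 3 days; on this read-out lower numbers stand for stronger inhibition and higher numbers for weaker inhibition. Compound 2 `CNc1nc(NCc2ccc(NS(=O)(=O)c3ccc(C)cc3)cc2)c2ccccc2n1` gives 5800 nM. Compound 3 `Cc1ccc(S(=O)(=O)Nc2ccc(CNc3nc(N4CCN(C)CC4)nc4ccccc34)cc2)cc1` reaches only the limit of the assay, > 20000 nM. Compound 1 `CN1CCN(c2nc(NCc3ccc(NC(=O)c4ccncc4)cc3)c3ccccc3n2)CC1` likewise reaches only the limit, > 20000 nM. The cores of compound 3 and compound 2 differ as methylamino in place of 4-methylpiperazin-1-yl on an aromatic carbon, and this gave an at least 3.4-fold higher number from compound 2 to compound 3 (0.53 log units; beyond the scatter). Compound 1 differs from compound 3 by (pyridin-4-yl)carbonyl in place of (4-methylphenyl)sulfonyl on a nitrogen on an aromatic ring, which gave a step that the two limits leave unreadable from compound 3 to compound 1 because of the limit of > 20000 nM in this assay, at which 2 of the 3 values shown sit.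

Compound 4 `CNc1nc(NCc2ccc(NC(=O)c3ccncc3)cc2)c2ccccc2n1` has not yet been measured. For the measured compounds named here, it differs from compound 2 by (pyridin-4-yl)carbonyl in place of (4-methylphenyl)sulfonyl on a nitrogen on an aromatic ring, and this is the same change as the one from compound 3 to compound 1, made at the same place. Since the earlier step is unreadable, the expectation for compound 4 rests mainly on the value of compound 2, 5800 nM, and the step from compound 2 to compound 4 is expected to be a 1.4-fold higher number from compound 2 to compound 4 (0.14 log units; within the scatter). Compound 4 is therefore estimated at 8000 nM, within a range of 2000 nM to 30000 nM.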

Compound 4, half-maximal inhibitory concentration: > 20000 nM
Compound 4 ended at the assay's limit; the forecaster's own chance of this, stated with the estimate: 30%; at least 2.5-fold (0.39 log units) between middle value and limit.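

On the core that carries methylamino, putting (pyridin-4-yl)carbonyl in place of (4-methylphenyl)sulfonyl on the nitrogen gave an at least 3.4-fold higher number from compound 2 to compound 4 (0.53 log units; beyond the scatter) in this assay, so on this core the change weakened inhibition. The value of compound 4, > 20000 nM, is a limit of the assay and not a number. Whether the change behaves the same way on the core that carries 4-methylpiperazin-1-yl is not shown: the step from compound 3 to compound 1 and the step from compound 1 to compound 4 cannot be read, because each has a limit at both ends: the limit of > 20000 nM in this assay, at which 3 of the 4 values shown sit.

The compounds shown leave open whether the loss follows the amide link or the pyridine ring, a question that a benzoyl cap or a pyridine-4-sulfonyl cap on the core of compound 2 would help to separate. Also open, on these data alone, is how a dimethylamino group or a morpholine would compare with methylamino on the aromatic carbon.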